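A few compounds are considered here, and "the series" means these few. Any claim that something is new, unique, unknown or untested is made for them only; others in the source may bear on it.

Of the compounds shown here, three have been measured in a functional assay on cells for agonist activity at Glucose-dependent insulinotropic receptor (Homo sapiens), read by a luciferase reporter, with a stated time of 4 h; a lower number here means that less compound is needed, a higher number that more compound is needed for the effect. Compound 2 `CC(C)(C)OC(=O)N1CCC(c2coc3c(Nc4ccc(S(C)(=O)=O)cc4F)ncnc23)CC1` gives 129 nM, the highest of the three numbers; compound 1 `CC(=O)c1cnc(N2CCC(c3coc4c(N5CCc6cc(S(C)(=O)=O)ccc65)ncnc34)CC2)nc1` gives 78 nM, a gap that lies within the usual scatter, while compound 3 `CS(=O)(=O)c1ccc2c(c1)CCN2c1ncnc2c(C3CCN(c4ncc(Cl)cn4)CC3)coc12` gives 42 nM, a gap beyond it. Among the compounds with values here, the only single-point step, a 1.9-fold lower number from compound 1 to compound 3 (0.27 log units; within the scatter), concerns a chloro in place of an acetyl on an aromatic carbon and does not touch the part altered here. Compound 4 `CN(c1ccc(S(C)(=O)=O)cc1F)c1ncnc2c(C3CCN(C(=O)OC(C)(C)C)CC3)coc12` differs from compound 2 by methyl in place of hydrogen on a nitrogen on an aromatic ring. Within the data shown here, no measured step covers a change of this kind, so nothing supports expecting a shift beyond the scatter in this assay. Compound 4 is therefore expected to give about 120 nM, between 35 nM and 400 nM, which would mean a 1.1-fold lower number from compound 2 to compound 4 (0.03 log units; within the scatter).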

Compound 4, half-maximal effective concentration: > 1000 nM
Compound 4: a limit, no number; the forecaster's own chance of this, stated with the estimate: 5%; middle value at least 8.3-fold (0.92 log units) from the limit.
By their numbers in this assay, from the lowest: compounds 3, 1 and 2 (each within the scatter of the next, the first and the last beyond it). At a limit, above all of these: compound 4.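

In this assay, within the data shown here, this nitrogen on an aromatic ring proves sensitive to change: methyl in place of hydrogen gives an at least 7.7-fold higher number from compound 2 to compound 4 (0.88 log units; beyond the scatter), whereas the only earlier step lay within the scatter and concerned a different part of the molecule. Compound 4 gives a limit of the assay, not a number: the limit of > 1000 nM in this assay, at which 1 of the 4 values shown sits.

As far as these compounds go, the true size of this step therefore remains unknown. Also open, from the compounds shown here alone, is whether ethyl, a longer chain on this nitrogen, would give a measurable number or the same limit.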